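Cytotoxicity notes on a small series of three analogues

This account rests on a few compounds, and the source may have more. Where it says the series, first, only, none or still open, it means among the compounds named here.

Measured so far:
compound 1 `CNc1nc(Cl)nc2c1ncn2[C@H]1C[C@H](N=[N+]=[N-])[C@@H](CO)O1` — > 100000 nM
compound 2 `CC(C)(CO)Nc1nc(N)nc2c1ncn2[C@H]1C[C@H](N=[N+]=[N-])[C@@H](CO)O1` — > 100000 nM
compound 3 `COc1nc(OC)c2ncn([C@H]3C[C@H](N=[N+]=[N-])[C@@H](CO)O3)c2n1` — > 100000 nM

All three readings are limits of the assay, not numbers. In an ADME assay on PBMC cells (Homo sapiens) for cytotoxicity, with a stated time of 5 days (a higher number here means a weaker inhibitor, a lower number a stronger inhibitor), compound 1 gives > 100000 nM, a limit. Compound 2 gives > 100000 nM in this assay, again a limit. Compound 3 gives > 100000 nM in this assay, also a limit. The whole set therefore stands at the limit of > 100000 nM in this assay, at which 3 of the 3 values shown sit, and compound 1 is not set apart from the other two in any way the data can show; no ordering among the three can be read from them.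

Compound 4 `[N-]=[N+]=N[C@H]1C[C@H](n2cnc3c(N)nc(Cl)nc32)O[C@@H]1CO` is the next compound to go into this assay. Against compound 1 it differs by hydrogen in place of methyl on a nitrogen on an aromatic ring; cut one bond further out, the change reads methylamino to amino. For the measured compounds named here, with all three measured compounds sitting at the limit, no step gives a size to go by, and the change from compound 1 to compound 4 is small. The expected step from compound 1 to compound 4 is a step that the limit leaves unreadable from compound 1 to compound 4, that is, none beyond the scatter, with a further limit the most likely outcome. Compound 4 is estimated at 150000 nM in this assay, in the range 50000 nM to 500000 nM.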

Compound 4, half-maximal inhibitory concentration: 35800 nM
Compound 4: middle estimate off by 4.2-fold (0.62 log units), on the high side; measured number below the stated range.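

In this assay, for the compounds shown here, hydrogen in place of methyl on a nitrogen on an aromatic ring gives an at least 2.7-fold lower number from compound 1 to compound 4 (0.44 log units; beyond the scatter), so this position is the first place where a change registers in the read-out. Compound 4 gives 35800 nM, the only true number among the compounds shown, which means that a change as small as methylamino to amino is enough to bring a compound of this series within the measurable range. The step gives a lower bound and not a size, since its starting point is a limit: the limit of > 100000 nM in this assay, at which 3 of the 4 values shown sit.

As far as these compounds go, whether the reading follows the size of the group on that nitrogen stays open, as one pair cannot separate a trend from a single step, and an ethylamino or a dimethylamino group at this place would test that. Also open, from the compounds shown here alone, is whether the same change from methylamino to amino would give a measurable number on a core carrying a methoxy group in place of the chlorine, since a single pair speaks only for the core of compound 1.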